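A few compounds are considered here, and "the series" means these few. Any claim that something is new, unique, unknown or untested is made for them only; others in the source may bear on it.

Measured in an ADME assay on microsomes from liver (Homo sapiens) for metabolic stability, with a stated time of 10 min; on this read-out lower numbers stand for a less stable compound and higher numbers for a more stable compound:

Compound 1 `CC(C)OC(=O)NCCS(=O)(=O)NC(=O)c1ccc(Nc2nc(NC3(c4ccc(Cl)cc4)CC3)nc(OCC(F)(F)F)n2)cc1`: 100%
Compound 2 `Cc1ccccc1S(=O)(=O)NC(=O)c1ccc(Nc2nc(NC3(c4ccc(Cl)cc4)CC3)nc(OCC(F)(F)F)n2)cc1`: 100%
Compound 3 `CC(C)(C)NC(=O)NCCS(=O)(=O)NC(=O)c1ccc(Nc2nc(NC3(c4ccc(Cl)cc4)CC3)nc(OCC(F)(F)F)n2)cc1`: 96%

All three compounds share the same core and differ only in the group attached to the sulfonyl sulfur or to the carbonyl carbon of that side chain. The three values lie within the usual scatter of one another: a number 4 percentage points lower from compound 1 to compound 3 (within the scatter), and likewise a number 4 percentage points lower from compound 2 to compound 3 (within the scatter). Compound 3 therefore sits among the other two with no real separation from either.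

Compound 4 `CC(C)(C)OC(=O)NCCS(=O)(=O)NC(=O)c1ccc(Nc2nc(NC3(c4ccc(Cl)cc4)CC3)nc(OCC(F)(F)F)n2)cc1` differs from compound 3 in a single place: tert-butoxy in place of (tert-butyl)amino on a carbonyl carbon. The measured step that bears most directly on this is a number 4 percentage points lower from compound 1 to compound 3 (within the scatter), which also exchanged the group on that same carbonyl carbon, from isopropoxy to (tert-butyl)amino, without moving the read-out beyond the scatter. The change to compound 4 gives that carbonyl carbon a tert-butoxy group, a close relative of the isopropoxy of compound 1, which gave 100%. No step beyond the scatter is expected: a number 2 percentage points higher from compound 3 to compound 4 (within the scatter). Compound 4 is accordingly estimated at 98%, with a range from 88% to 100%.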

Compound 4, percent of the compound remaining in the liver assay: 92%
Compound 4: middle estimate off by 6 percentage points, on the high side, and the stated range covers the measured number.
By their numbers in the liver assay, from the lowest: compounds 4, 3, 1 and 2 (each within the scatter of the next).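

Compound 4 shows that the carbonyl carbon tolerates this exchange in the liver assay, where none of its steps leaves the scatter: a number 4 percentage points lower from compound 3 to compound 4 (within the scatter), a number 8 percentage points lower from compound 2 to compound 4 (within the scatter) and a number 8 percentage points lower from compound 1 to compound 4 (within the scatter). A second read-out separates the pair, as in a physicochemical assay for permeability, using PAMPA, at pH 7.4 (on this read-out higher numbers stand for higher permeability and lower numbers for lower permeability), compound 3 gives 49 nm/s and compound 4 gives 111 nm/s. The swap of (tert-butyl)amino, with its hydrogen-bond donor, for tert-butoxy, which has none, thus raises permeability modestly while stability stays within the scatter: the measured apparent permeability of compound 3, 49 nm/s, and of compound 4, 111 nm/s, a 2.3-fold higher number (0.36 log units; beyond the scatter).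

Two compounds cannot show whether the same rise would appear in other pairs on this side chain. Also open, on these data alone, is how a methoxy or a dimethylamino group on that carbonyl carbon would fare in the liver assay and the physicochemical assay.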